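Moving the fluorine: from compound 2 to compound 4

This account rests on a few compounds, and the source may have more. Where it says the series, first, only, none or still open, it means among the compounds named here.

Compound 1 `COc1nc2ccc(Br)cc2cc1C(c1ccccc1)n1cc(-c2ccccc2)nn1`, compound 2 `COc1nc2ccc(Br)cc2cc1C(c1ccccc1)n1cc(-c2ccccc2F)nn1` and compound 3 `COc1nc2ccc(Br)cc2cc1C(c1ccccc1)n1cc(CO)nn1` share one core and differ only in the group carried on the five-membered aromatic ring with 3 nitrogen. In an ADME assay on PC-3 cells (Homo sapiens) for cytotoxicity, read by sulforhodamine B assay, with a stated time of 48 h, tested at 10 uM (a lower number here means less inhibition, a higher number more inhibition at the concentration tested (going by the name of the read-out)), compound 1 gives 5.97%, compound 2 gives 13.4% and compound 3 gives 4.65%. Compound 2 carries the highest of the three numbers as they stand, but all three lie within the scatter of one another: a number 7.4 percentage points higher from compound 1 to compound 2 (within the scatter), a number 8.8 percentage points lower from compound 2 to compound 3 (within the scatter) and a number 1.3 percentage points lower from compound 1 to compound 3 (within the scatter) are each too small to count as a change. Phenyl, 2-fluorophenyl and hydroxymethyl on that aromatic carbon have not moved the read-out beyond noise.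

Compound 4 `COc1nc2ccc(Br)cc2cc1C(c1ccccc1)n1cc(-c2cccc(F)c2)nn1` is the next step from compound 2: 3-fluorophenyl in place of 2-fluorophenyl on an aromatic carbon. The two compounds have the same atoms, joined differently. Every measured step at this aromatic carbon was flat, so none speaks for a shift in this assay beyond the scatter in either direction. The step of a number 3.4 percentage points lower from compound 2 to compound 4 (within the scatter) is therefore expected to be flat. On that basis compound 4 is estimated at 10%, with a range from 0% to 22%.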

Compound 4, a percentage reported as inhibition, at one concentration (the size of the read-out at that concentration, not a potency): 14.6%
Estimate against measurement, compound 4: 4.6 percentage points below, and the stated range covers the measured number.
By their numbers in this assay, from the lowest: compounds 3, 1, 2 and 4 (each within the scatter of the next).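

In this assay, within the data shown here, the swap of 2-fluorophenyl for 3-fluorophenyl, the only step at this aromatic carbon that keeps the same atoms and changes how they are joined, gives a number 1.2 percentage points higher from compound 2 to compound 4 (within the scatter) and so shows no dependence on where the fluorine sits for these two isomers. The other two new steps, a number 8.6 percentage points higher from compound 1 to compound 4 (within the scatter) for fluoro in place of hydrogen and a number 10 percentage points higher from compound 3 to compound 4 (within the scatter) for 3-fluorophenyl in place of hydroxymethyl, also fail to leave the scatter, so phenyl, 2-fluorophenyl, 3-fluorophenyl and hydroxymethyl on this carbon cannot be told apart at the concentration tested. Nothing available explains this flat picture or bears on what lies behind it.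

Still open, going by these compounds, is whether any group on this aromatic carbon moves the read-out beyond the scatter, for example an aminomethyl group or a carboxylic acid in place of hydroxymethyl, a longer alkyl chain, or a trifluoromethyl or methoxy group on the phenyl ring. Also open, on these data alone, is whether a change elsewhere on the shared core, such as a nitrile in place of the bromine, would do what these changes on the triazole-bearing side have not.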